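Cyclohexylmethyl in place of cyclopentyl: working notes

The source may hold more compounds than are shown below. What is called first, only, known or untested is meant among the compounds shown, and "the series" means these compounds.

Within the data shown here, in a functional assay on PC-3 cells (Homo sapiens) for cytotoxicity, read by WST assay, with a stated time of 72 h (on this read-out higher numbers stand for weaker inhibition and lower numbers for stronger inhibition), compound 3 (`O=C1Nc2c(ccc(F)c2F)C1(c1ccc(O)cc1)C1CCCC1`) gives 8.2 nM, the lowest of the three numbers so far. Compound 1 (`O=C1Nc2c(ccc(F)c2F)C1(c1ccc(O)cc1)c1ccc(F)c(F)c1`) gives 19 nM, and compound 2 (`O=C1Nc2c(ccc(F)c2F)C1(c1ccncc1)c1ccc(O)cc1`) gives 110 nM. Next is compound 4 (`O=C1Nc2c(ccc(F)c2F)C1(CC1CCCCC1)c1ccc(O)cc1`), with cyclohexylmethyl in place of cyclopentyl on a saturated ring carbon.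

All three measured steps fall at this same carbon. Cyclopentyl in place of 3,4-difluorophenyl gave a 2.3-fold lower number from compound 1 to compound 3 (0.36 log units; beyond the scatter), a modest step. Cyclopentyl in place of pyridin-4-yl gave a 13-fold lower number from compound 2 to compound 3 (1.13 log units; beyond the scatter), a large one. Pyridin-4-yl in place of 3,4-difluorophenyl gave a 5.8-fold higher number from compound 1 to compound 2 (0.76 log units; beyond the scatter), again modest. Among the measured compounds shown here, the number in this assay therefore moves with the group held here, but no measured step exchanges one saturated ring group for another, so these sizes serve only as a loose guide. A small move toward a higher number is expected, possibly none beyond the scatter. The expected step is a 1.7-fold higher number from compound 3 to compound 4 (0.23 log units; within the scatter). Compound 4 is estimated at 14 nM, with an expected range from 5 nM to 40 nM.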

Compound 4, half-maximal inhibitory concentration: > 1000 nM
Compound 4 ended at the assay's limit (the forecaster's own chance of this, stated with the estimate: 2%); middle value at least 71-fold (1.85 log units) from the limit.
By their numbers in this assay, from the lowest: compound 3; then compound 1; then compound 2. At a limit, above all of these: compound 4.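

In this assay the value of compound 4 is a limit and not a number: the limit of > 1000 nM in this assay, at which 1 of the 4 values shown sits. This carbon therefore does not accept every saturated ring group, and the exchange of cyclopentyl for cyclohexylmethyl gives an at least 120-fold higher number from compound 3 to compound 4 (2.08 log units; beyond the scatter), a larger step than any seen here before. Cyclohexylmethyl also reads worse than both aromatic groups, with an at least 52-fold higher number from compound 1 to compound 4 (1.72 log units; beyond the scatter) and an at least 9.0-fold higher number from compound 2 to compound 4 (0.95 log units; beyond the scatter), so compound 4 goes against the order suggested by compound 3, where a saturated ring group gave the lowest number.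

Still open, on these data alone, is whether the jump follows the larger ring or the methylene link, and cyclohexyl directly on this carbon or cyclopentylmethyl would separate the two. Also open, as far as these compounds go, is how an amine or a carboxylic acid at this position would read in this assay.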